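Removing One Ester From Compound 1: Expected Solubility

The source may hold more compounds than are shown below. What is called first, only, known or untested is meant among the compounds shown, and "the series" means these compounds.

Compound 1, `COc1ccc(C(=O)OC[C@H]2O[C@@H](n3cnc4c(OC)ncnc43)[C@@H](OC(=O)c3ccc(OC)cc3)[C@@H]2OC(=O)c2ccc(OC)cc2)cc1`, gives < 5000 nM.
Compound 2, `COc1ccc(C(=O)O[C@H]2[C@H](OC(=O)c3ccc(OC)cc3)[C@@H](CO)O[C@H]2n2cnc3c(OC)ncnc32)cc1`, gives 5000 nM.
Compound 3, `COc1ccc(C(=O)OC[C@H]2O[C@@H](n3cnc4c(OC)ncnc43)[C@@H](OC(=O)c3ccc(OC)cc3)[C@@H]2O)cc1`, gives 6000 nM.

In a physicochemical assay for solubility, in phosphate buffer (a higher number here means a more soluble compound, a lower number a less soluble compound), compound 1 gives < 5000 nM, which is a limit of the assay and not a number, so only a bound is known for it. Compound 2 gives 5000 nM and compound 3 gives 6000 nM, the two sitting within the scatter of each other. Compound 4, `COc1ccc(C(=O)OC[C@H]2O[C@@H](n3cnc4c(OC)ncnc43)[C@@H](O)[C@@H]2OC(=O)c2ccc(OC)cc2)cc1`, has not yet been measured. It differs from compound 1 by hydrogen in place of (4-methoxyphenyl)carbonyl on an oxygen on a saturated carbon. Within the data shown here, two measured steps bear on this change: a number no lower from compound 1 to compound 2 (the limit leaves the size open) and an at least 1.2-fold higher number from compound 1 to compound 3 (0.07 log units; that floor lies within the scatter). Each of these likewise replaces a (4-methoxyphenyl)carbonyl group by hydrogen on an oxygen on a saturated carbon, though at a different oxygen, and neither moved the number downward. For compound 4 the expected step is therefore an at least 1.1-fold higher number from compound 1 to compound 4 (0.04 log units; that floor lies within the scatter), that is, no change beyond the scatter. The estimate for compound 4 is 5500 nM, with an expected range from 3000 nM to 10000 nM.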

Compound 4, solubility: 45000 nM
Beside the measured number, compound 4's estimate is 8.2-fold (0.91 log units) below it; measured number outside the range, above it.
By their numbers in this assay, from the lowest: compounds 2 and 3 (each within the scatter of the next); then compound 4.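

In this assay, hydrogen in place of (4-methoxyphenyl)carbonyl at this oxygen gives an at least 9.0-fold higher number from compound 1 to compound 4 (0.95 log units; beyond the scatter), so this change can carry the number well past the scatter. The same replacement at the other two oxygens gave a number no lower from compound 1 to compound 2 (the limit leaves the size open) and an at least 1.2-fold higher number from compound 1 to compound 3 (0.07 log units; that floor lies within the scatter), neither read as beyond the scatter, so in these compounds the result depends on which oxygen loses the group. The value of compound 1 is a limit of the assay and not a number, so the new step is only a floor: the limit of < 5000 nM in this assay, at which 1 of the 4 values shown sits.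

The compounds shown leave open whether the free hydroxy matters here or only the loss of the (4-methoxyphenyl)carbonyl group, a question that a methyl ether or an acetyl ester on the same oxygen could address. They also do not tell how an amine in place of the hydroxy would read in this assay.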